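This account rests on a few compounds, and the source may have more. Where it says the series, first, only, none or still open, it means among the compounds named here.

Two compounds share one core and differ only at the far end of the chain. Compound 1 `O=C(OCCCc1ccc(F)c(F)c1)N(c1ccccc1)C1CN2CCC1CC2` gives 100 nM in an assay on CHO cells for displacement of a labelled ligand from muscarinic acetylcholine receptor M5 (Homo sapiens), read by scintillation counting, with a stated time of 2 h (on this read-out lower numbers stand for stronger inhibition and higher numbers for weaker inhibition), and compound 2 `COc1ccc(CCCOC(=O)N(c2ccccc2)C2CN3CCC2CC3)cc1F` gives 260 nM, so compound 2 stands at the higher, weaker end of the two numbers measured. The step from compound 1 to compound 2 was a 2.6-fold higher number from compound 1 to compound 2 (0.41 log units; beyond the scatter). Compound 3 `O=C(OCCCc1ccc(Cl)c(Cl)c1)N(c1ccccc1)C1CN2CCC1CC2` is reached from compound 2 by 3,4-dichlorophenyl in place of 3-fluoro-4-methoxyphenyl on a saturated chain carbon, three bonds along the chain from an oxygen next to a carbonyl group. The methoxy appears only in compound 2, whose reading 260 nM is the weaker one. Compound 3 carries no such group, and its expected step is a 2.2-fold lower number from compound 2 to compound 3 (0.34 log units; beyond the scatter). Compound 3 is estimated at 120 nM, within 50 nM to 300 nM.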

Compound 3, inhibition constant: 130 nM
The estimate for compound 3 lay 1.1-fold (0.03 log units) below the measured number; measured number inside the range.
By their numbers in this assay, from the lowest: compounds 1, 3 and 2 (each within the scatter of the next, the first and the last beyond it).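

Changing 3,4-difluorophenyl to 3,4-dichlorophenyl gives a 1.3-fold higher number from compound 1 to compound 3 (0.11 log units; within the scatter), so these two end groups cannot be told apart in this assay. Changing 3-fluoro-4-methoxyphenyl to 3,4-dichlorophenyl gives a 2.0-fold lower number from compound 2 to compound 3 (0.30 log units; within the scatter), which leaves the step between compound 1 and compound 2 as the only one beyond the scatter. No measurement available here explains these readings. The compounds shown leave open how an amine or a carboxylic acid on the aromatic ring would read, and what a longer chain would do.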